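The source may hold more compounds than are shown below. What is called first, only, known or untested is meant among the compounds shown, and "the series" means these compounds.

Measured in a functional assay on HFF cells (Homo sapiens) for cytotoxicity; a lower number here means a stronger inhibitor, a higher number a weaker inhibitor:
- compound 1 `Cc1ccc(S(=O)(=O)NN2C(=S)S/C(=C\c3ccc(Cl)c(Cl)c3)C2O)cc1` gives > 100000 nM
- compound 2 `O=C1/C(=C/c2ccc([N+](=O)[O-])cc2)SC(=S)N1NS(=O)(=O)c1ccccc1` gives > 100000 nM
- compound 3 `N#Cc1ccc(/C=C2\SC(=S)N(NS(=O)(=O)c3ccccc3)C2=O)cc1` gives > 100000 nM

All of these readings are limits, not numbers. Compound 1 has only a limit in this assay and gives no measured potency to start from. The other two compounds offer no better reference, and the whole set reads (the limit of > 100000 nM in this assay, at which 3 of the 3 values shown sit).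

Compound 4 `O=S(=O)(NN1C(=S)S/C(=C\c2ccc(Cl)c(Cl)c2)C1O)c1ccc(F)cc1` is the next compound, and it keeps the core of compound 1. The change is fluoro in place of methyl on an aromatic carbon, para to a large group, or 4-methylphenyl to 4-fluorophenyl.

Among the compounds with values here, only one measured step is available, a step that the two limits leave unreadable from compound 2 to compound 3. It is a different replacement, and both of its ends are limits, so it gives no size to carry over. The expectation therefore rests on compound 1 at > 100000 nM and on the shared limit of the set. No step beyond the usual scatter is expected in this assay, and no direction can be assigned. The expected step is a number no higher from compound 1 to compound 4 (the limit leaves the size open).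

For compound 4 the estimate is 100000 nM, with an expected range from 40000 nM to 200000 nM, and another report as a limit is the likeliest outcome.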

Compound 4, half-maximal inhibitory concentration: > 100000 nM
Compound 4: only a limit was reported; the forecaster's own chance of this, stated with the estimate: 85%; the middle value sits exactly at the limit.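

Compound 1 and compound 4 are both reported only as limits, so no step can be read for 4-methylphenyl to 4-fluorophenyl. The compounds shown leave open what potency any of them has in this assay, and whether any change in the series shifts it: the limit of > 100000 nM in this assay, at which 4 of the 4 values shown sit.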